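Thiourea Analogue Bearing a 2-Nitrophenyl Amine: Expected Cytotoxicity

A few compounds are considered here, and "the series" means these few. Any claim that something is new, unique, unknown or untested is made for them only; others in the source may bear on it.

Compound 1 `CCOC(=O)C1=C(C)NC(=O)NC1c1cn(C(=O)CNc2ccc([N+](=O)[O-])cc2C)c2ccccc12` gives 600 ug/mL in this study.
Compound 3 `CCOC(=O)C1=C(C)NC(=O)NC1c1cn(C(=O)CNc2ccccc2[N+](=O)[O-])c2ccccc12` gives 250 ug/mL.
For compound 2 `CCOC(=O)C1=C(C)NC(=S)NC1c1cn(C(=O)CNc2ccc([N+](=O)[O-])cc2C)c2ccccc12` the assay reports only a limit, > 1000 ug/mL.

In a functional assay on HCT-116 cells (Homo sapiens) for cytotoxicity, read by MTT assay, with a stated time of 72 h (on this read-out higher numbers stand for weaker inhibition and lower numbers for stronger inhibition), the change from compound 1 to compound 3, (2-nitrophenyl in place of 2-methyl-4-nitrophenyl on an amine nitrogen), gave a 2.4-fold lower number from compound 1 to compound 3 (0.38 log units; beyond the scatter). Compound 4 `CCOC(=O)C1=C(C)NC(=S)NC1c1cn(C(=O)CNc2ccccc2[N+](=O)[O-])c2ccccc12` has not yet been measured; it differs from compound 2 by the same change, (2-nitrophenyl in place of 2-methyl-4-nitrophenyl on an amine nitrogen), at the same place. How the core of compound 2 differs from that of compound 1 is not broken down here. For compound 4 a step of roughly the earlier size is expected, an at least 2.0-fold lower number from compound 2 to compound 4 (0.30 log units; that floor lies within the scatter), though because compound 2 stands at the limit of > 1000 ug/mL in this assay, at which 1 of the 3 values shown sits, the starting point is itself unknown and a limit may be reported again. Compound 4 is therefore estimated at 500 ug/mL, expected to lie between 200 ug/mL and 1500 ug/mL.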

Compound 4, half-maximal inhibitory concentration: > 1000 ug/mL
Compound 4: only a limit was reported; the forecaster's own chance of this, stated with the estimate: 45%; at least 2.0-fold (0.30 log units) between middle value and limit.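

Compound 2 and compound 4 both sit at a limit in this assay, so no step between them can be read: the limit of > 1000 ug/mL in this assay, at which 2 of the 4 values shown sit.

The compounds shown leave open whether 2-nitrophenyl in place of 2-methyl-4-nitrophenyl changes the cytotoxicity on the core of compound 2.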